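Urea Inhibitors: Oxadiazole Exchanged for Methylpiperazine

This account rests on a few compounds, and the source may have more. Where it says the series, first, only, none or still open, it means among the compounds named here.

Measured compounds:
compound 1, `Cc1cc(C)c(NC(=O)N(Cc2ccc(-c3n[nH]c(C)n3)cc2)C2CCCCCC2)c(C)c1`, 120 nM
compound 2, `Cc1cc(C)c(NC(=O)N(Cc2ccc(-c3nnc(C)o3)cc2)C2CCCCCC2)c(C)c1`, 27 nM

In an assay on microsomes from intestine for inhibition of acyl-CoA:cholesterol acyltransferase (Oryctolagus cuniculus) (on this read-out lower numbers stand for stronger inhibition and higher numbers for weaker inhibition), compound 2 gives the lowest of the two numbers; the step of a 4.4-fold lower number from compound 1 to compound 2 (0.65 log units; beyond the scatter) separates it from compound 1. Compound 3, `Cc1cc(C)c(NC(=O)N(Cc2ccc(N3CCN(C)CC3)cc2)C2CCCCCC2)c(C)c1`, differs from compound 2 by 4-methylpiperazin-1-yl in place of 5-methyl-1,3,4-oxadiazol-2-yl on an aromatic carbon. Among the measured compounds shown here, the single measured step swapped one five-membered aromatic ring for another and says nothing about a six-membered non-aromatic ring at that position, so no direction can be drawn from it. Compound 3 is therefore expected near compound 2, with a wide range: 45 nM (10 nM to 250 nM), a step of a 1.7-fold higher number from compound 2 to compound 3 (0.22 log units; within the scatter) expected to stay within the scatter.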

Compound 3, half-maximal inhibitory concentration: 57 nM
The estimate for compound 3 lay 1.3-fold (0.10 log units) below the measured number; the range from low to high includes it.
By their numbers in this assay, from the lowest: compound 2; then compound 3; then compound 1.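

In this assay, the aromatic carbon para to a large group does not need a five-membered aromatic ring: the six-membered non-aromatic 4-methylpiperazin-1-yl gives a 2.1-fold higher number from compound 2 to compound 3 (0.32 log units; beyond the scatter) against the oxadiazole, yet a 2.1-fold lower number from compound 1 to compound 3 (0.32 log units; beyond the scatter) against the triazole. No measurement at hand explains either step.

Going by these compounds, it remains open whether the methyl on 4-methylpiperazin-1-yl contributes to this result. Also open, on these data alone, is how a morpholine ring or a dimethylamino group would compare at this position.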